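Swapping the Amide Aryl: Pyridine to Pyrimidine

A few compounds are considered here, and "the series" means these few. Any claim that something is new, unique, unknown or untested is made for them only; others in the source may bear on it.

Compound 2 `O=C(CN1CCN(c2ccccn2)CC1)Nc1cccnc1` gives 6410 nM in an assay on HEK293 cells for displacement of a labelled ligand from D(4) dopamine receptor (Homo sapiens), read by scintillation counting, with a stated time of 60 min (a higher number here means a weaker inhibitor, a lower number a stronger inhibitor), the highest number among the three measured compounds. Compound 3 `O=C(CN1CCN(c2ccc(Cl)cn2)CC1)Nc1cccnc1` sits within the scatter of it at 5000 nM, while compound 1 `CCc1cccc(NC(=O)CN2CCN(c3ccccn3)CC2)c1` gives 67.9 nM, far lower. Compound 4 `O=C(CN1CCN(c2ccccn2)CC1)Nc1cncnc1` differs from compound 2 only by pyrimidin-5-yl in place of pyridin-3-yl on an amide-type nitrogen. The step from compound 1 to compound 2, a 94-fold higher number from compound 1 to compound 2 (1.97 log units; beyond the scatter), shows that the group on this amide nitrogen can move the number a great deal; the step of a 1.3-fold lower number from compound 2 to compound 3 (0.11 log units; within the scatter) concerns a different position and barely registers. For the measured compounds named here, no measured pair tests adding a ring nitrogen here, so a modest rise in the inhibition constant is expected, giving a 1.7-fold higher number from compound 2 to compound 4 (0.23 log units; within the scatter). Compound 4 is estimated at 11000 nM, between 4000 nM and 30000 nM.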

Compound 4, inhibition constant: 39300 nM
Compound 4: the middle estimate sits 3.6-fold (0.55 log units) below what was measured; measured number outside the range, above it.
By their numbers in this assay, from the lowest: compound 1; then compounds 3 and 2 (each within the scatter of the next); then compound 4.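

In this assay, for the compounds shown here, adding a second ring nitrogen at this amide-type nitrogen is not a silent change: it gives a 6.1-fold higher number from compound 2 to compound 4 (0.79 log units; beyond the scatter) and takes the number further up than the earlier compounds showed. Replacing 3-ethylphenyl with pyrimidin-5-yl gives a 580-fold higher number from compound 1 to compound 4 (2.76 log units; beyond the scatter), so the full span at this place is wider than it first appeared.

A plain phenyl or an ethyl-bearing pyridin-3-yl would help separate the role of the ethyl group from that of the ring nitrogens. Nothing shown explains why the number rises.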